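Swapping the Amide Substituent in a Weakly Cytotoxic Pair

The source may report more compounds than this note shows. Statements on the series, on what has been measured and on what is new or still open speak of the compounds shown alone.

The study measures cytotoxicity in a functional assay on QGY7701 cells (Homo sapiens) for cytotoxicity, read by MTT assay, with a stated time of 24 h; a lower number here means a stronger inhibitor, a higher number a weaker inhibitor. For the measured compounds named here, compound 1 `C=CC1=C(C(=O)NCc2ccc(C)cc2)C(c2ccc(F)cc2)OC1` is the only compound for which a number is reported: in this assay compound 1 gives 62100 nM, a weak result. Compound 2 `C=CC1=C(C(=O)NC(C)(C)C)C(c2ccc(Cl)c(Cl)c2)OC1` reaches only a limit of the assay, and in this assay compound 2 gives > 100000 nM. The remaining evidence is the limit of > 100000 nM in this assay, at which 1 of the 2 values shown sits, so compound 1 stands alone with a number and nothing yet shows whether its neighbours would be stronger or weaker.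

Compound 3 `C=CC1=C(C(=O)Nc2ccccc2)C(c2ccc(F)cc2)OC1` has not been measured. It differs from compound 1 by phenyl in place of 4-methylbenzyl on an amide-type nitrogen. Going by the values given here, no measured pair in this set follows such a change, so the step can only be guessed from how weak compound 1 is, at 62100 nM. The step of a 1.0-fold lower number from compound 1 to compound 3 (0.01 log units; within the scatter) is expected to be small and not beyond the usual scatter, in either direction. Compound 3 is therefore estimated to give 60000 nM in this assay, with a likely range from 25000 nM to 150000 nM.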

Compound 3, half-maximal inhibitory concentration: 46700 nM
For compound 3 the middle estimate is 1.3-fold (0.11 log units) above the measured one; the range from low to high includes it.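

Phenyl in place of 4-methylbenzyl on an amide-type nitrogen gives a 1.3-fold lower number from compound 1 to compound 3 (0.12 log units; within the scatter), the first step that can be read at this position. In this assay the two compounds therefore cannot be told apart, and this swap of one aromatic carbon ring for another does not by itself lift the shared core out of weak cytotoxicity. Compound 2 remains a limit of the assay and not a number: the limit of > 100000 nM in this assay, at which 1 of the 3 values shown sits.

For the compounds shown here, compound 2 differs from the other two compounds in more than one place, so no step to it can be read. On these data alone, whether a different kind of group on this nitrogen, such as a chain ending in an amine or a carboxylic acid, would move the number beyond the scatter remains open.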